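Swapping a Carbamate for a Hydroxyl in an Adrenergic Series

This account rests on a few compounds, and the source may have more. Where it says the series, first, only, none or still open, it means among the compounds named here.

Measured so far:
Compound 1 `O=S(=O)(Nc1cccc2c1CCCC2c1c[nH]cn1)c1ccc2ccccc2c1` gives 692 nM.
Compound 2 `CN(C)S(=O)(=O)Nc1cccc2c1CCCC2c1c[nH]cn1` gives 977 nM.
Compound 3 `COC(=O)Nc1cccc2c1CCCC2c1c[nH]cn1` gives 148 nM.

These three compounds share one core and differ only in the group attached to it on one aromatic carbon. All were tested in an assay on isolated protein for binding affinity to Alpha-1A adrenergic receptor (Bos taurus), read by radioligand binding; on this read-out higher numbers stand for weaker inhibition and lower numbers for stronger inhibition. Among the three, compound 3 has the lowest number, beyond the scatter from both compound 1 and compound 2. Within the data shown here, the single one-place step recorded is a 6.6-fold lower number from compound 2 to compound 3 (0.82 log units; beyond the scatter), a modest move to stronger binding.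

Compound 4 `Oc1cccc2c1CCCC2c1c[nH]cn1` is not yet measured. Its change from compound 3 is hydroxy in place of (methoxycarbonyl)amino on an aromatic carbon. Among the measured compounds shown here, no measured step removes the whole nitrogen-bearing group in this way; the recorded step only exchanges what sits on that nitrogen. The three measured values span a modest range, so a step of similar or smaller size is expected here, with the direction uncertain. Compound 4 is therefore estimated to give 300 nM, within 60 nM to 1500 nM, a step of a 2.0-fold higher number from compound 3 to compound 4 (0.31 log units; beyond the scatter).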

Compound 4, inhibition constant: 115 nM
Estimate against measurement, compound 4: 2.6-fold (0.42 log units) above; low and high end bracket the measured number.
By their numbers in this assay, from the lowest: compounds 4 and 3 (each within the scatter of the next); then compounds 1 and 2 (each within the scatter of the next).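

In this assay, replacing the whole (methoxycarbonyl)amino group on this aromatic carbon with a lone hydroxy gives a 1.3-fold lower number from compound 3 to compound 4 (0.11 log units; within the scatter), so the nitrogen and carbonyl of the larger group are not required for binding in this range. Against the (dimethylsulfamoyl)amino group, the same hydroxy gives an 8.5-fold lower number from compound 2 to compound 4 (0.93 log units; beyond the scatter), which shows that a single heavy atom at this position can be enough and that a larger group here can go with a higher number. Nothing available explains why these groups compare as they do. The compounds shown leave open how a methoxy group, a plain amine or a bare hydrogen on this carbon would compare with hydroxy. They also leave open whether the same holds when other parts of the shared core change.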